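A few compounds are considered here, and "the series" means these few. Any claim that something is new, unique, unknown or untested is made for them only; others in the source may bear on it.

Working notes on the cyclopentenone ester series.

Compound 1 `CC/C=C\C[C@H]1C(=O)C=C[C@H]1CC(=O)OCC` is the reference. Going by the values given here, in an ADME assay on RAW264.7 cells (Mus musculus) for cytotoxicity, read by MTT assay, with a stated time of 24 h (on this read-out lower numbers stand for higher toxicity in this test and higher numbers for lower toxicity in this test), compound 1 gives 146 uM, the highest of the two numbers so far; its nearest neighbour is compound 2 `CC/C=C\C[C@H]1C(=O)C=C[C@H]1CC(=O)Oc1ccc(O)cc1`, which in this assay gives 49 uM. Among the compounds with values here, the one step that connects them, 4-hydroxyphenyl in place of ethyl on an oxygen next to a carbonyl group, reads a 3.0-fold lower number from compound 1 to compound 2 (0.47 log units; beyond the scatter).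

Compound 3 `CC/C=C\C[C@H]1C(=O)C=C[C@H]1CC(=O)OC(C)(C)C` is not yet measured. It differs from compound 1 as follows: tert-butyl in place of ethyl on an oxygen next to a carbonyl group

Within the data shown here, no measured step swaps one alkyl group for another at this oxygen; the only step in hand, from compound 1 to compound 2, exchanges an alkyl for an aryl group and so bears on the new change only loosely. With a change that stays within alkyl groups, nothing in the data points to a shift beyond the scatter in this assay.

For compound 3 in this assay the expected value is 130 uM, with a range from 70 uM to 250 uM. The step this estimate implies is a 1.1-fold lower number from compound 1 to compound 3 (0.05 log units; within the scatter), expected to fall inside the usual scatter.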

Compound 3, half-maximal toxic concentration: 33 uM
For compound 3 the middle estimate is 3.9-fold (0.60 log units) above the measured one; measured number below the stated range.
By their numbers in this assay, from the lowest: compounds 3 and 2 (each within the scatter of the next); then compound 1.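

In this assay the exchange of ethyl for tert-butyl reads a 4.4-fold lower number from compound 1 to compound 3 (0.65 log units; beyond the scatter) at this position, so on the oxygen next to a carbonyl group a change that stays within alkyl groups moves the number beyond the scatter, as the exchange of alkyl for aryl did. The tert-butyl and 4-hydroxyphenyl esters lie close together, with a 1.5-fold lower number from compound 2 to compound 3 (0.17 log units; within the scatter) in the same assay, so the two groups cannot be told apart here, and among the three compounds only compound 1, the ethyl ester, stands apart, with the highest number. Nothing in hand gives a reason for the step from ethoxy to tert-butoxy or for the closeness of compound 2 and compound 3.

Open, from the compounds shown here alone, is how methyl, isopropyl or a longer chain such as n-butyl would sit at this oxygen, and so whether the number falls gradually from ethyl to tert-butyl or changes only with the branched group. Also open, going by these compounds, is whether plain phenyl would read like the 4-hydroxyphenyl ester, and how an amide in place of the ester would read on the same core.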